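The source may report more compounds than this note shows. Statements on the series, on what has been measured and on what is new or still open speak of the compounds shown alone.

Measured compounds in the series:
- compound 1, `COc1ccc(-c2cc(C(C)=O)c3[nH]c(-c4ccc(F)cc4)cc3c2)cc1`: 16800 nM
- compound 2, `CC(=O)c1cc(/C=C/c2ccccc2)cc2cc(-c3ccccc3)[nH]c12`: > 100000 nM

In a functional assay on MCF7 cells (Homo sapiens) for cytotoxicity, read by MTT assay, with a stated time of 2 days (a lower number here means that less compound is tolerated, a higher number that more compound is tolerated), compound 1 gives 16800 nM. Compound 2 is different: in this assay compound 2 reaches only the limit of the measurement, > 100000 nM, and no number is known for it. This is the situation noted as the limit of > 100000 nM in this assay, at which 1 of the 2 values shown sits, so compound 2 stands at the top end of what the measurement can report, and its true value is not fixed.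

The next compound, compound 3, `CC(=O)c1cc(/C=C/c2ccccc2)cc2cc(-c3ccc(F)cc3)[nH]c12`, is compound 2 with one change: fluoro in place of hydrogen on an aromatic carbon. Going by the values given here, no measured pair in this set shows this same change, so the size of the step is not known from the data. A single fluorine added to an aromatic ring of this kind is a small change, and the step from compound 2 to compound 3 in this assay is expected to stay within the scatter, with no direction favoured: a number no higher from compound 2 to compound 3 (the limit leaves the size open). Compound 3 is therefore expected to give about 100000 nM in this assay, with a range from 30000 nM to 300000 nM, and a good chance that only a limit is reported again.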

Compound 3, concentration lethal to 50% of the cells: > 100000 nM
Compound 3: no number, only a limit; the forecaster's own chance of this, stated with the estimate: 60%; the middle value sits exactly at the limit.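

In this assay compound 3 gives > 100000 nM, which is a limit and not a number, so fluoro on this ring does not bring the 2-phenylethenyl compounds into the range where a number can be read. Going by these compounds alone, the step for phenyl to 4-fluorophenyl cannot be read, as both compounds in that pair sit at the same ceiling: the limit of > 100000 nM in this assay, at which 2 of the 3 values shown sit. With the 4-fluorophenyl group now shared, the first readable comparison concerns the other aromatic substituent: 2-phenylethenyl in place of 4-methoxyphenyl gives an at least 5.9-fold higher number from compound 1 to compound 3 (0.77 log units; beyond the scatter), a step beyond the scatter whose full size remains unknown.

As far as these compounds go, the true values of compound 2 and compound 3 remain open, and with them whether fluoro in place of hydrogen changes the result in this assay at all. Also open, from the compounds shown here alone, is whether an amine or a carboxylic acid in place of the 2-phenylethenyl group would give a readable number on this core, and how such a compound would compare with compound 1.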